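The source may report more compounds than this note shows. Statements on the series, on what has been measured and on what is new or still open speak of the compounds shown alone.

Measured so far:
Compound 1 `C#CCNC(=O)/C(C)=C(\C)c1ccc(OC)cc1`: in a toxicity assay on the whole organism (strain Icem-CET (SPF Caw)) for cytotoxicity, with Mus musculus as the target (a higher number here means that more compound is needed for the effect, a lower number that less compound is needed), compound 1 gives 150 mg/kg.
Compound 2 `C/C(C(=O)NC1CC1)=C(/C)c1ccc(F)cc1`: in this assay compound 2 gives 110 mg/kg.
Compound 3 `C/C(C(=O)NC1CC1)=C(/C)c1ccc(Cl)cc1`: in this assay compound 3 gives 350 mg/kg.

Compound 3 stands highest of the three in this assay, so the most compound is needed for its effect; compound 1 comes nearest and compound 2 lies furthest, and both gaps are beyond the scatter. The change now considered is methoxy in place of chloro on an aromatic carbon, which gives compound 4 `COc1ccc(/C(C)=C(\C)C(=O)NC2CC2)cc1`. Only one measured step exists among these compounds, a 3.2-fold higher number from compound 2 to compound 3 (0.50 log units; beyond the scatter), a swap of one halogen for another; it does not involve a methoxy group, so it bears only loosely on this step. Compound 1 does carry a methoxy group and gives 150 mg/kg in this assay, but it differs from compound 3 in the amide part as well, so it offers only a hint. On that hint, a modest move toward a lower number is expected, with an expected step of a 2.1-fold lower number from compound 3 to compound 4 (0.31 log units; beyond the scatter). Compound 4 is therefore estimated at 170 mg/kg, in a range from 80 mg/kg to 350 mg/kg.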

Compound 4, dose for half-maximal effect: 250 mg/kg
Estimate against measurement, compound 4: 1.5-fold (0.17 log units) below; the range from low to high includes it.
By their numbers in this assay, from the lowest: compounds 2, 1, 4 and 3 (each within the scatter of the next, the first and the last beyond it).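

In this assay, on this aromatic carbon para to a large group, methoxy in place of chloro gives a 1.4-fold lower number from compound 3 to compound 4 (0.15 log units; within the scatter), so the two groups cannot be told apart here, even though methoxy brings a hydrogen-bond acceptor that chloro lacks. Fluoro does stand apart from methoxy, with a 2.3-fold higher number from compound 2 to compound 4 (0.36 log units; beyond the scatter), so the earlier gap between the two halogens was not special to chloro. For the compounds shown here, the first pair that differs only at the amide nitrogen, with cyclopropyl in place of propargyl, gives a 1.7-fold higher number from compound 1 to compound 4 (0.22 log units; within the scatter), so with methoxy on the ring this swap also stays within the scatter.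

No measurement at hand explains why fluoro stands apart from the other two groups. Going by these compounds, how an amine or a carboxylic acid at this ring position, or a longer chain on the amide nitrogen, would compare remains open.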